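Swapping the amide substituent of compound 1 for 4-hydroxycyclohexyl

The source may report more compounds than this note shows. Statements on the series, on what has been measured and on what is new or still open speak of the compounds shown alone.

Measured in a physicochemical assay for solubility; a lower number here means a less soluble compound, a higher number a more soluble compound:
Compound 1 `CNC(=O)c1cc(C(=O)N[C@H]2[C@@H]3COC[C@@H]32)c([C@@H](C)c2ccccc2)o1`: >= 131 ug/mL
Compound 2 `CNC(=O)c1cc(C(=O)NCCO)n([C@@H](C)c2ccccc2)n1`: >= 139 ug/mL
Compound 3 `CCCNC(=O)c1cc(C(=O)NC)nn1[C@@H](C)c1ccccc1`: >= 132 ug/mL

Compound 1 does not stand at a number but at a limit of this assay (the limit of >= 131 ug/mL in this assay, at which 1 of the 3 values shown sits). Compound 2 likewise sits at a limit (the limit of >= 139 ug/mL in this assay, at which 1 of the 3 values shown sits). Compound 3 also sits at a limit (the limit of >= 132 ug/mL in this assay, at which 1 of the 3 values shown sits). Compound 4 `CNC(=O)c1cc(C(=O)N[C@H]2CC[C@H](O)CC2)c([C@@H](C)c2ccccc2)o1` differs from compound 1 in one place: a group of 7 heavy atoms (6 carbon, 1 oxygen; one six-membered non-aromatic ring of carbon only) in place of a group of 6 heavy atoms (5 carbon, 1 oxygen; one three-membered non-aromatic ring of carbon only, one five-membered non-aromatic ring with 1 hetero atom), on an amide-type nitrogen. Within the data shown here, the only measured step, a step that the two limits leave unreadable from compound 2 to compound 3, runs between two limits and has no readable size, so it offers no guide to the direction or size of the new change. With every value shown sitting at a limit, compound 4 is expected to sit near that limit as well, estimated at 150 ug/mL with a range of 75 ug/mL to 300 ug/mL. The expected step that the limit leaves unreadable from compound 1 to compound 4 is therefore estimated as none beyond the scatter.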

Compound 4, solubility: >= 184 ug/mL
Compound 4: no number, only a limit (the forecaster's own chance of this, stated with the estimate: 75%); middle value at least 1.2-fold (0.08 log units) away from the limit.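

Compound 1 and compound 4 both stand at limits in this assay, so the step between them cannot be read. The compounds shown leave open what actual number any of them would reach in this assay.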